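Growth inhibition from compound 3 to compound 4

The source may report more compounds than this note shows. Statements on the series, on what has been measured and on what is new or still open speak of the compounds shown alone.

Compound 1 `Cc1cc(=O)c2c(O)cc(OCc3ccccc3)c([C@H]3CCN(C)C[C@H]3O)c2o1`: 14%
Compound 2 `Cc1cc(=O)c2c(O)cc(OCc3ccco3)c([C@H]3CCN(C)C[C@H]3O)c2o1`: 7%
Compound 3 `Cc1oc2c([C@H]3CCN(C)C[C@H]3O)c(O)cc(O)c2c(=O)c1C(O)c1ccc(F)c(Br)c1`: 9%

All three compounds were tested in a functional assay on MIA PaCa-2 cells (Homo sapiens) for inhibition, read by MTT assay, with a stated time of 48 h, tested at 10 uM; a higher number here means more inhibition of growth at the concentration tested, a lower number less inhibition of growth. At 9%, compound 3 has the second highest of the three numbers, but it lies within the scatter of both compound 1 and compound 2, so the numbers do not separate the three compounds.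

Compound 4 `Cc1oc2c([C@H]3CCN(C)C[C@H]3O)c(O)cc(O)c2c(=O)c1C(O)c1cc(F)cc(F)c1` has not yet been measured. It differs from compound 3 in a single place, on a saturated chain carbon bound to an aromatic carbon and an oxygen on a saturated carbon: 3,5-difluorophenyl in place of 3-bromo-4-fluorophenyl on a saturated chain carbon bound to an aromatic carbon and an oxygen on a saturated carbon. Within the data shown here, the only measured step is a number 7 percentage points lower from compound 1 to compound 2 (within the scatter). Among the measured compounds shown here, that step concerns a different group, so it bears on this change only indirectly, and no measured step involves the 3-bromo-4-fluorophenyl group itself. With this evidence, no change beyond the scatter is expected in this assay.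

The expected step is no change at the digits printed from compound 3 to compound 4 (within the scatter). Compound 4 is estimated at 9%, with an expected range of 1% to 19%.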

Compound 4, percent growth inhibition at one concentration: 6%
Compound 4: the middle estimate sits 3 percentage points above what was measured, within the range that was stated.
By their numbers in this assay, from the lowest: compounds 4, 2, 3 and 1 (each within the scatter of the next).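

In this assay, 3,5-difluorophenyl in place of 3-bromo-4-fluorophenyl gives a number 3 percentage points lower from compound 3 to compound 4 (within the scatter), the first step measured at this position, on a saturated chain carbon bound to an aromatic carbon and an oxygen on a saturated carbon. This exchange removes the bromine and keeps the count of 8 heavy atoms in the group, and within this pair the number does not separate the two halogen patterns. Nothing measured here explains the result.

The compounds shown leave open whether the aromatic ring at this position matters at all, since both groups compared are halogenated phenyl rings. Whether an amine or a carboxylic acid on that ring, or a plain butyl chain in its place, would move the number beyond the scatter also remains unanswered.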